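The source may report more compounds than this note shows. Statements on the series, on what has been measured and on what is new or still open speak of the compounds shown alone.

Values in a functional assay on NCI-H508 cells (Homo sapiens) for antiproliferative activity, read by MTT assay, with a stated time of 72 h; a lower number here means a stronger inhibitor, a higher number a weaker inhibitor:
- compound 1 `COc1cc(/C=C2\CCC/C(=C\c3ccc(O)c(O)c3)C2=O)cc(OC)c1OC`: 7000 nM
- compound 2 `COc1ccc(/C=C2\CCC/C(=C\c3cc(OC)c(OC)c(OC)c3)C2=O)cc1OC`: 1700 nM

Compound 1 stands at the higher of the two numbers, so it is the weaker inhibitor of this pair. The next compound to be measured is compound 3 `COc1cc(/C=C2\CCC/C(=C\c3ccc(O)c(Cl)c3)C2=O)cc(OC)c1OC`. Its structural change is chloro in place of hydroxy on an aromatic carbon, with chloro in place of hydroxy on an aromatic carbon, turning 3,4-dihydroxyphenyl into 3-chloro-4-hydroxyphenyl.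

Going by the values given here, only one measured step alters the same group: a 4.1-fold lower number from compound 1 to compound 2 (0.61 log units; beyond the scatter), a modest step for 3,4-dimethoxyphenyl in place of 3,4-dihydroxyphenyl. Among the compounds with values here, no chloro compound has been measured, so this guide is thin. Within the data shown here, a modest move toward a lower number in this assay is expected, possibly no larger than that step. The expected change is a 2.3-fold lower number from compound 1 to compound 3 (0.37 log units; beyond the scatter). For compound 3 the estimated value is 3000 nM, with an expected range of 1100 nM to 8000 nM.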

Compound 3, half-maximal inhibitory concentration: 4000 nM
Beside the measured number, compound 3's estimate is 1.3-fold (0.12 log units) below it; measured number inside the range.
By their numbers in this assay, from the lowest: compound 2; then compounds 3 and 1 (each within the scatter of the next).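

In this assay the exchange of chloro for hydroxy on this aromatic carbon, ortho to a hydroxy group, gives a 1.8-fold lower number from compound 1 to compound 3 (0.24 log units; within the scatter) and so does not separate the two compounds, even though one hydroxy of the 3,4-dihydroxyphenyl group leaves. Set against the fully methylated group, 3-chloro-4-hydroxyphenyl gives a 2.4-fold higher number from compound 2 to compound 3 (0.37 log units; beyond the scatter) and compound 2 keeps the lowest number of the three, so in this small set the 3,4-dimethoxyphenyl group is the only change that moves the number beyond the scatter. No data at hand explain either step.

Open, on these data alone, is whether a fluoro, a bromo, a methyl or an amino group on this same aromatic carbon would read any differently from chloro. Also open, as far as these compounds go, is what a methoxy in place of the remaining hydroxy would do in the chloro compound.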